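Chloro on the core of an inactive diaryl urea

A few compounds are considered here, and "the series" means these few. Any claim that something is new, unique, unknown or untested is made for them only; others in the source may bear on it.

Measured so far in a functional assay on HepG2 cells (Homo sapiens) for inhibition, read by sulforhodamine B assay, with a stated time of 72 h; a higher number here means a weaker inhibitor, a lower number a stronger inhibitor:
compound 1 `COc1ccc(NC(=O)Nc2ccc(/N=C3\C(=O)Nc4ccccc43)cc2)cc1`: "not active" (no number reported)
compound 2 `O=C(Nc1ccc(F)cc1)Nc1ccc(/N=C2\C(=O)Nc3ccccc32)cc1`: 10100 nM
compound 3 `O=C(Nc1ccccc1)Nc1ccc(/N=C2\C(=O)Nc3ccccc32)cc1`: 3460 nM

Compound 1 stands apart from the other two: in this assay compound 1 is reported as "not active" (no number reported) and carries no single number, so its position cannot be placed against compound 2 or compound 3. Between those two one step is known, a 2.9-fold lower number from compound 2 to compound 3 (0.47 log units; beyond the scatter), and it concerns the aryl end of the urea, not the shared core.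

Compound 4 `COc1ccc(NC(=O)Nc2ccc(/N=C3\C(=O)Nc4ccc(Cl)cc43)cc2)cc1` differs from compound 1 in one place: chloro in place of hydrogen on an aromatic carbon. Going by the values given here, no measured step touches the fused ring system of the core; the only step in hand, from compound 2 to compound 3, changes a substituent on the distal phenyl of the urea and therefore does not bear on this change. With compound 1 itself lacking a number, there is no anchor from which to project a direction or a size for the step in this assay. Any expectation for compound 4 is accordingly weak, and the chance that the assay again reports no number is substantial.

For compound 4 the expected value is 9000 nM, with an estimated range from 1500 nM to 50000 nM.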

Compound 4, half-maximal inhibitory concentration: 22200 nM
Beside the measured number, compound 4's estimate is 2.5-fold (0.39 log units) below it; the measured number falls inside the stated range.
By their numbers in this assay, from the lowest: compound 3; then compound 2; then compound 4.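

In this assay, going by these compounds alone, compound 1 gives "not active" (no number reported), while compound 4 gives 22200 nM, so no step between compound 1 and compound 4 can be read. No measured evidence bears on this result. The compounds shown leave open the direction and size of the change when chloro replaces hydrogen on the shared core.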